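The source may report more compounds than this note shows. Statements on the series, on what has been measured and on what is new or still open speak of the compounds shown alone.

Working notes on the series.

Compound 1 `CC1(C)c2[nH]nc(NC(=O)c3ccccc3)c2CN1Cc1ccc(F)cc1` gives 1180 nM in an assay on Sf21 cells for inhibition of high affinity nerve growth factor receptor (Homo sapiens), read by HTRF, with a stated time of 30 min, in the presence of a further agent that is not named here; a lower number here means a stronger inhibitor, a higher number a weaker inhibitor. Compound 2 `CC1(C)c2[nH]nc(NC(=O)c3ccccc3)c2CN1Cc1cccc(F)c1F` gives 200 nM in this assay, and the step is a 5.9-fold lower number from compound 1 to compound 2 (0.77 log units; beyond the scatter). Compound 3 `CC1(C)c2[nH]nc(NC(=O)c3ccccc3)c2CN1Cc1ccc(F)cc1F` gives 2320 nM in this assay. Compound 3 differs from compound 1 by fluoro in place of hydrogen on an aromatic carbon, and the step is a 2.0-fold higher number from compound 1 to compound 3 (0.29 log units; within the scatter). Between the two difluoro compounds the step is a 12-fold higher number from compound 2 to compound 3 (1.06 log units; beyond the scatter). Compound 2 carries the lowest number of the three, and both of its steps to the others lie beyond the scatter.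

Compound 4 `CC1(C)c2[nH]nc(NC(=O)c3ccc(F)cc3)c2CN1Cc1cccc(F)c1F` has not yet been measured in this assay. It differs from compound 2 by fluoro in place of hydrogen on an aromatic carbon. The same kind of change was made from compound 1 to compound 3, but the place is not the same: there it was ortho to a large group and meta to a fluoro group, whereas in compound 4 it is para to a large group. The two cores differ by 2,3-difluorophenyl in place of 4-fluorophenyl on a saturated chain carbon bound to an amine nitrogen in a ring.

The step from compound 2 to compound 4 in this assay is expected to be about a 1.3-fold higher number from compound 2 to compound 4 (0.10 log units; within the scatter), set beside the earlier step, because the earlier step of a 2.0-fold higher number from compound 1 to compound 3 (0.29 log units; within the scatter) stayed within the scatter, with the reservation that the place differs. Compound 4 is estimated at 250 nM, expected to fall between 90 nM and 700 nM.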

Compound 4, half-maximal inhibitory concentration: 210 nM
Compound 4: middle estimate off by 1.2-fold (0.08 log units), on the high side; measured number inside the range.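

In this assay, fluoro in place of hydrogen on the benzoyl ring of the core of compound 2, which gives the (4-fluorophenyl)carbonyl group, is a 1.1-fold higher number from compound 2 to compound 4 (0.02 log units; within the scatter), so the new fluoro leaves the number within the scatter on this core. Set beside the earlier case, the two steps do not differ beyond what repeated measurements would give: the same change on two cores in this assay, a 2.0-fold higher number (0.29 log units; within the scatter) from compound 1 to compound 3 and a 1.1-fold higher number (0.02 log units; within the scatter) from compound 2 to compound 4, 1.9-fold (0.27 log units) apart, within the scatter of two such steps. This does not show that one fluoro effect carries from core to core, as the new fluoro sits on the benzoyl ring in compound 4 but on the other aromatic ring in compound 3, so the two steps share a kind of change and not a place, and they rest on a single pair of cores.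

The compounds shown leave open what a group larger than fluoro, such as methoxy, an amine or a carboxylic acid, would do in the place of the new fluoro on the benzoyl ring. Going by these compounds, they also leave open whether the benzoyl ring stays this insensitive with other substitution on the second ring, where the pattern of fluoro groups matters far more, as in a 12-fold higher number from compound 2 to compound 3 (1.06 log units; beyond the scatter), and where chloro groups in place of the fluoro groups of the 2,3-difluorophenyl group remain untested here.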